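The source may hold more compounds than are shown below. What is called first, only, known or untested is meant among the compounds shown, and "the series" means these compounds.

Of the compounds shown here, three built on one shared core have been tested so far. Compound 1 `CCn1cc(C(=O)O)c(=O)c2cc(F)c(N3CCN(C(=N)NS(=O)(=O)c4ccc(C)cc4)CC3)cc21` gives, in a functional assay on A549 cells (Homo sapiens) for antiproliferative activity, read by MTT assay, with a stated time of 72 h (on this read-out higher numbers stand for weaker inhibition and lower numbers for stronger inhibition), a value of 71 nM. Compound 2 `Cc1ccc(S(=O)(=O)NC(=N)N2CCN(c3cc4c(cc3F)c(=O)c(C(=O)O)cn4C3CC3)CC2)cc1` gives 71 nM in this assay, and the change from cyclopropyl in place of ethyl on an aromatic nitrogen gave no change at the digits printed from compound 1 to compound 2 (within the scatter). Compound 3 `N=C(NS(=O)(=O)c1ccc(Cl)cc1)N1CCN(c2cc3c(cc2F)c(=O)c(C(=O)O)cn3C2CC2)CC1` gives 71 nM in this assay, and chloro in place of methyl on an aromatic carbon gave no change at the digits printed from compound 2 to compound 3 (within the scatter). Among the compounds with values here, compound 3 therefore stands level with compounds 1 and 2, with every measured step so far lying inside the scatter of the method.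

Compound 4 `N=C(NS(=O)(=O)c1ccccc1C(F)(F)F)N1CCN(c2cc3c(cc2F)c(=O)c(C(=O)O)cn3C2CC2)CC1` is the next step: 2-(trifluoromethyl)phenyl in place of 4-chlorophenyl on a sulfonyl sulfur. Within the data shown here, of the measured steps, only the one from compound 2 to compound 3 touches the same aryl ring on the sulfonyl sulfur, and it moved nothing beyond the scatter. The present change swaps a larger group, so some uncertainty remains, but no step beyond the scatter is expected in either direction. Compound 4 is expected to give about 75 nM in this assay, in a range from 30 nM to 190 nM. The expected step is a 1.1-fold higher number from compound 3 to compound 4 (0.02 log units; within the scatter).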

Compound 4, half-maximal inhibitory concentration: 71 nM
Beside the measured number, compound 4's estimate is 1.1-fold (0.02 log units) above it; the measured number falls inside the stated range.
By their numbers in this assay, from the lowest: compounds 1, 2, 3 and 4 (each within the scatter of the next).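

In this assay, the aryl group on the sulfonyl sulfur has now been changed by more than one small substituent, and 2-(trifluoromethyl)phenyl in place of 4-chlorophenyl gave no change at the digits printed from compound 3 to compound 4 (within the scatter), while 2-(trifluoromethyl)phenyl in place of 4-methylphenyl gave no change at the digits printed from compound 2 to compound 4 (within the scatter). Within the data shown here, the earlier step only put chloro in place of methyl, whereas here a group of 10 heavy atoms enters for one of 7 and the substituent's place on the ring differs as well, so this position accepts a wider change than the earlier compounds showed. Nothing available explains why the number holds steady at this position.

The compounds shown include no group on the sulfonyl sulfur that moves this read-out beyond the scatter. On these data alone, it remains open whether an amine or a carboxylic acid on the phenyl ring, or a plain methyl in place of the whole ring, would do so.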